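Sulfonamide series: replacing the fused core of compound 2

The compounds below may be only part of what the source reports. "The series", "measured", "known", "first", "only" and "open" are said of these compounds alone.

Within the data shown here, compound 2 `CCN(CC)C(=O)CN(c1cc2c(C)nsc2cc1Cl)S(=O)(=O)c1ccc(OC)c(OC)c1` gives 29 nM in a functional assay on CHO cells for inhibition of Orexin/Hypocretin receptor type 1 (Homo sapiens), read by FLIPR and calcium flux (on this read-out higher numbers stand for weaker inhibition and lower numbers for stronger inhibition), the higher of the two numbers in hand; compound 1 `CCN(C(=O)CN(c1cc2c(C)nsc2cc1Cl)S(=O)(=O)c1ccc(OC)c(OC)c1)c1ccccn1` gives 8 nM, and the single measured step is a 3.6-fold higher number from compound 1 to compound 2 (0.56 log units; beyond the scatter). Compound 3 `CCN(CC)C(=O)CN(c1cc(C(C)C)ccc1Cl)S(=O)(=O)c1ccc(OC)c(OC)c1` differs from compound 2 at the sulfonamide nitrogen: a group of 10 heavy atoms (9 carbon, 1 chlorine; one six-membered aromatic ring of carbon only) in place of a group of 11 heavy atoms (8 carbon, 1 nitrogen, 1 sulfur, 1 chlorine; one five-membered aromatic ring with 2 hetero atoms, one six-membered aromatic ring of carbon only), on a sulfonamide nitrogen. Among the measured compounds shown here, that change at the amide-type nitrogen does not touch the sulfonamide nitrogen, so no measured step bears on the present change. A step of a 2.8-fold higher number from compound 2 to compound 3 (0.44 log units; beyond the scatter) toward weaker inhibition is therefore expected only as a guess with wide bounds. Compound 3 is estimated at 80 nM, within 20 nM to 400 nM.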

Compound 3, half-maximal inhibitory concentration: 888 nM
Compound 3: the middle estimate sits 11-fold (1.05 log units) below what was measured; measured number above the stated range.
By their numbers in this assay, from the lowest: compound 1; then compound 2; then compound 3.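

In this assay, the group on the sulfonamide nitrogen proves a sensitive point in the series: 2-chloro-5-isopropylphenyl in the place of the two-ring group gives a 31-fold higher number from compound 2 to compound 3 (1.49 log units; beyond the scatter). A single aromatic ring of carbon only therefore does not stand in for that group here. No measurement in hand accounts for this step.

Still open, as far as these compounds go, is whether a pyridine or a thiophene on that nitrogen would hold the number closer to compound 2. From the compounds shown here alone, it is also open whether pyridin-2-yl on the amide-type nitrogen would recover any of the loss seen with 2-chloro-5-isopropylphenyl.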